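A few compounds are considered here, and "the series" means these few. Any claim that something is new, unique, unknown or untested is made for them only; others in the source may bear on it.

Measured compounds:
compound 1 `CC(C)(C)c1ccc(CNCCCNS(=O)(=O)c2cc(C(F)(F)F)cc(C(F)(F)F)c2)cc1`, in a functional assay on HPAC cells (Homo sapiens) for inhibition, read by MTT assay, with a stated time of 72 h (a higher number here means a weaker inhibitor of growth, a lower number a stronger inhibitor of growth), compound 1 gives 2300 nM;
compound 2 `O=S(=O)(NCCCCNCc1ccc(Br)cc1)c1cc(C(F)(F)F)cc(C(F)(F)F)c1`, in this assay compound 2 gives 2000 nM.

The two numbers lie within the usual scatter of each other, so compound 1 cannot be set apart from compound 2 on these measurements; the values of the two compounds show only that both sit in the same region. Compound 3 `O=S(=O)(NCCCNCc1cccc(Cl)c1)c1cc(C(F)(F)F)cc(C(F)(F)F)c1` has not been measured in this assay. It departs from compound 1 in one place: 3-chlorophenyl in place of 4-(tert-butyl)phenyl on a saturated chain carbon bound to an amine nitrogen. Going by the values given here, no measured pair separates this particular exchange, and compound 2 carries both a different halogen and a different chain, so it offers no step of its own. The step from compound 1 to compound 3 in this assay is expected to be small, a 1.1-fold higher number from compound 1 to compound 3 (0.04 log units; within the scatter), with no direction beyond the scatter. For compound 3 the estimate in this assay is 2500 nM, with a range from 900 nM to 7000 nM.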

Compound 3, concentration for 50% growth inhibition: 2700 nM
Compound 3: middle estimate off by 1.1-fold (0.03 log units), on the low side, and the stated range covers the measured number.
By their numbers in this assay, from the lowest: compounds 2, 1 and 3 (each within the scatter of the next).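

In this assay, going by these compounds alone, the exchange of 4-(tert-butyl)phenyl for 3-chlorophenyl on a saturated chain carbon bound to an amine nitrogen gives a 1.2-fold higher number from compound 1 to compound 3 (0.07 log units; within the scatter) and thus provides the first reading at this place, where the number stays within the scatter despite the change of substituent and of its location on the phenyl ring. The further step of a 1.4-fold higher number from compound 2 to compound 3 (0.13 log units; within the scatter) also stays within the scatter, so the three compounds still cannot be told apart in this assay. Nothing measured here offers an explanation for this result.

On these data alone, whether an amine or a carboxylic acid on the phenyl ring would move the number beyond the scatter remains open. So does the effect of a longer chain or of replacing the two trifluoromethyl groups of the shared core.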